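Sulfonate esters on HT-1080 cells: amide to carbamoyl step

The source may hold more compounds than are shown below. What is called first, only, known or untested is meant among the compounds shown, and "the series" means these compounds.

Measured so far:
- compound 1, `CCCCCC(=O)Nc1ccc(S(=O)(=O)Oc2ccccc2C(C)C)cc1`: 6300 nM
- compound 2, `CCCCCC(=O)Nc1ccc(S(=O)(=O)Oc2ccccc2I)cc1`: 9600 nM
- compound 3, `CCCCCNC(=O)Nc1ccc(S(=O)(=O)Oc2ccccc2I)cc1`: 6900 nM

In a functional assay on HT-1080 cells (Homo sapiens) for antiproliferative activity, read by sulforhodamine B assay, with a stated time of 48 h (on this read-out lower numbers stand for stronger inhibition and higher numbers for weaker inhibition), compound 1 gives the lowest of the three numbers, but the set is tight: compound 3 lies nearest and compound 2 furthest, and both gaps sit within the scatter, so no order among the three can be claimed.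

Compound 4, `CC(C)c1ccccc1OS(=O)(=O)c1ccc(NC(=O)NCC2CCCC2)cc1`, is not yet measured. It differs from compound 1 in one place: (cyclopentylmethyl)amino in place of pentyl on a carbonyl carbon. Of the measured steps, only a 1.4-fold lower number from compound 2 to compound 3 (0.14 log units; within the scatter) bears on it, since that step also replaces pentyl on the carbonyl carbon with an amino-bearing group; it stayed within the scatter. Among the compounds with values here, the change to compound 4 carries the same kind of replacement, here with a five-membered ring added, and the set holds no step that tests such a ring. The expected step is therefore a 1.1-fold lower number from compound 1 to compound 4 (0.06 log units; within the scatter), small and not clearly beyond the scatter.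

Compound 4 is expected to give about 5500 nM in this assay, estimated between 2500 nM and 12000 nM.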

Compound 4, half-maximal inhibitory concentration: 6000 nM
Compound 4: the middle estimate sits 1.1-fold (0.04 log units) below what was measured; the range from low to high includes it.
By their numbers in this assay, from the lowest: compounds 4, 1, 3 and 2 (each within the scatter of the next).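

In this assay the exchange of pentyl for (cyclopentylmethyl)amino on the carbonyl carbon gives a step within the scatter (a 1.1-fold lower number from compound 1 to compound 4 (0.02 log units; within the scatter)). The earlier step at this carbon (a 1.4-fold lower number from compound 2 to compound 3 (0.14 log units; within the scatter)) involved pentylamino and the iodo compounds; the new one extends the observation to the isopropyl compounds and to an entering group with a five-membered non-aromatic ring of carbon only. Nothing available bears on this result.

Still open, from the compounds shown here alone, is whether a benzylamino group, a shorter chain such as ethylamino, or a chain ending in a carboxylic acid on this carbonyl carbon would give a step beyond the scatter. Also open, going by these compounds, is how (cyclopentylmethyl)amino reads out with iodo in place of isopropyl on the shared core.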